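Relocating the Methoxy Group on the Benzyl Amide

The source may report more compounds than this note shows. Statements on the series, on what has been measured and on what is new or still open speak of the compounds shown alone.

Measured compounds:
compound 1, `COc1ccc(CNC(=O)c2nc(-c3ccc(F)cc3)n(CC[C@@H](O)C[C@@H](O)CC(=O)O)c2C2CC2)cc1F`, 0.2 nM
compound 2, `COc1ccc(CNC(=O)c2nc(-c3ccc(F)cc3)n(CC[C@@H](O)C[C@@H](O)CC(=O)O)c2C2CC2)cc1`, 0.2 nM

In a functional assay on cells (Hepatocyte, Rattus norvegicus) for inhibition, read by scintillation counting, with a stated time of 4 h (on this read-out lower numbers stand for stronger inhibition and higher numbers for weaker inhibition), compound 2 stands level with compound 1; the step of no change at the digits printed from compound 1 to compound 2 (within the scatter) shows that hydrogen in place of fluoro on an aromatic carbon leaves the read-out unchanged within the scatter. Compound 3, `COc1ccccc1CNC(=O)c1nc(-c2ccc(F)cc2)n(CC[C@@H](O)C[C@@H](O)CC(=O)O)c1C1CC1`, differs from compound 2 by 2-methoxyphenyl in place of 4-methoxyphenyl on a saturated chain carbon bound to an amide-type nitrogen. Among the compounds with values here, no measured step concerns the methoxyphenyl group itself, so the measured data give no direct guide. Compound 3 is therefore expected to show only a modest weakening, a 2.5-fold higher number from compound 2 to compound 3 (0.40 log units; beyond the scatter), with an estimated value of 0.5 nM and a range from 0.15 nM to 2.5 nM.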

Compound 3, half-maximal inhibitory concentration: 0.1 nM
For compound 3 the middle estimate is 5.0-fold (0.70 log units) above the measured one, outside the stated range (below it).
By their numbers in this assay, from the lowest: compounds 3, 1 and 2 (each within the scatter of the next).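

In this assay the methoxy group of the benzyl amide can be carried as 2-methoxyphenyl as well as 4-methoxyphenyl, since the change gives a 2.0-fold lower number from compound 2 to compound 3 (0.30 log units; within the scatter) and the read-out does not separate the two. Against the 3-fluoro-4-methoxyphenyl group, 2-methoxyphenyl likewise gives a 2.0-fold lower number from compound 1 to compound 3 (0.30 log units; within the scatter) and again no separation. No measurement at hand accounts for this tolerance. As far as these compounds go, whether an ethoxy group, a hydroxyl or a dimethylamino group in place of the methoxy group would hold this level stays open. So does the effect of a longer chain between the amide nitrogen and the ring.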